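Swapping a Phenyl for an Ethylfuran on an Alkyne

A few compounds are considered here, and "the series" means these few. Any claim that something is new, unique, unknown or untested is made for them only; others in the source may bear on it.

Compound 1 `CNC(=O)[C@@]12C[C@@H]1[C@@H](n1cnc3c(NC)nc(C#Cc4ccccc4)nc31)[C@H](O)[C@@H]2O` was tested in an assay on CHO cells for displacement of a labelled ligand from adenosine receptor A1 (Homo sapiens), read by scintillation counting, with a stated time of 60 min, tested at 10 uM (a higher number here means more inhibition at the concentration tested (going by the name of the read-out), a lower number less inhibition), where compound 1 gives 18%. Compound 2 `CNC(=O)[C@@]12C[C@@H]1[C@@H](n1cnc3c(NC)nc(C#Cc4ccc(-c5ccccc5)cc4)nc31)[C@H](O)[C@@H]2O` carries a phenyl in place of hydrogen on an aromatic carbon; in this assay compound 2 gives 18%, so no change at the digits printed from compound 1 to compound 2 (within the scatter). Compound 3 `CNC(=O)[C@@]12C[C@@H]1[C@@H](n1cnc3c(NC)nc(C#Cc4cccnc4)nc31)[C@H](O)[C@@H]2O` has pyridin-3-yl in place of phenyl on a triple-bonded carbon; in this assay compound 3 gives 16%, and a number 2 percentage points lower from compound 1 to compound 3 (within the scatter), just as a number 2 percentage points lower from compound 2 to compound 3 (within the scatter). Compound 1 thus stands level with compound 2 at the digits shown, the two sharing the highest of the three numbers, with compound 3 within the scatter of both.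

Compound 4 `CCc1ccc(C#Cc2nc(NC)c3ncn([C@H]4[C@H](O)[C@H](O)[C@]5(C(=O)NC)C[C@H]45)c3n2)o1` is the next step from compound 1: 5-ethylfuran-2-yl in place of phenyl on a triple-bonded carbon. Among the compounds with values here, the steps that bear on it are those that exchange the group on the triple-bonded carbon, a number 2 percentage points lower from compound 1 to compound 3 (within the scatter) and a number 2 percentage points lower from compound 2 to compound 3 (within the scatter), neither beyond the scatter. A change of the same kind is therefore expected to move this assay by no change at the digits printed from compound 1 to compound 4 (within the scatter), no step beyond the scatter. Compound 4 is expected to give about 18%, between 5% and 32%.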

Compound 4, a percentage reported as inhibition, at one concentration (the size of the read-out at that concentration, not a potency): 18%
The estimate for compound 4 equals the measured number at the digits printed; the measured number falls inside the stated range.
By their numbers in this assay, from the lowest: compounds 3, 1, 2 and 4 (each within the scatter of the next).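

Within the data shown here, with 5-ethylfuran-2-yl on the triple-bonded carbon, a five-membered aromatic ring with 1 hetero atom now stands where the earlier compounds carry six-membered rings, and this assay shows no change at the digits printed from compound 1 to compound 4 (within the scatter) and a number 2 percentage points higher from compound 3 to compound 4 (within the scatter) and no change at the digits printed from compound 2 to compound 4 (within the scatter) for this group. The four groups at this position, which differ in ring size and in the hydrogen-bond acceptor count of the group, therefore all give numbers within the scatter of one another. Nothing on hand offers a reason for this.

Still open, from the compounds shown here alone, is whether a carboxylic acid or an amine at the end of a longer chain on the triple-bonded carbon would move the number beyond the scatter. These compounds also cannot show how a group at any other place on the shared core would behave.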